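The source may report more compounds than this note shows. Statements on the series, on what has been measured and on what is new or still open speak of the compounds shown alone.

Measured so far in a physicochemical assay, with a stated time of 6 min; a lower number here means a stronger inhibitor, a higher number a weaker inhibitor:
Compound 1 `O=C(Nc1ccc(F)cc1)Nc1nc(-c2cc3cc(Br)ccc3o2)cs1` gives > 200000 nM, a limit of the assay.
Compound 2 `O=C(Nc1ccc(Br)cc1)Nc1nc(-c2cc3ccccc3o2)cs1` gives > 200000 nM, a limit of the assay.
Compound 3 `Cc1ccc(NC(=O)Nc2nc(-c3cc4cc(Br)ccc4o3)cs2)cc1` gives > 200000 nM, a limit of the assay.

Compound 2 thus stands at the limit of this assay, and no number is known for it. Within the data shown here, the only measured step, a step that the two limits leave unreadable from compound 1 to compound 3, cannot be read, since both of its ends are limits (the limit of > 200000 nM in this assay, at which 3 of the 3 values shown sit). Compound 4 `O=C(Nc1nc(-c2cc3ccccc3o2)cs1)Nc1ccccc1[N+](=O)[O-]` differs from compound 2 by 2-nitrophenyl in place of 4-bromophenyl on an amide-type nitrogen, on an amide-type nitrogen whose other neighbour is a carbonyl carbon. Among the measured compounds shown here, no measured step involves a change of this kind, and every value so far sits at the limit (the limit of > 200000 nM in this assay, at which 3 of the 3 values shown sit), so no step of a particular size or direction is expected in this assay. Compound 4 is therefore estimated at 200000 nM, with a range from 50000 nM to 1000000 nM, most likely again only a limit. The step of a number no higher from compound 2 to compound 4 (the limit leaves the size open) that this estimate means is expected to be none beyond the scatter.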

Compound 4, half-maximal inhibitory concentration: 20300 nM
Beside the measured number, compound 4's estimate is 9.9-fold (0.99 log units) above it; measured number outside the range, below it.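

In this assay, 2-nitrophenyl in place of 4-bromophenyl on the amide-type nitrogen gives an at least 9.8-fold lower number from compound 2 to compound 4 (0.99 log units; beyond the scatter). This shows that a change at this position can bring a compound within the readable range of the assay, and compound 4 is the only compound shown with an actual number. The step from compound 1 to compound 3 still cannot be read, and the other values remain limits: the limit of > 200000 nM in this assay, at which 3 of the 4 values shown sit.

The compounds shown leave open whether the nitro group itself or the loss of the bromine accounts for this step. On these data alone, it is also open whether an amine or a carboxylic acid in place of the nitro group would give a similar number.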